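Replacing a carboxyphenyl with a carboxybenzyl on a fused quinazolinone core

The source may hold more compounds than are shown below. What is called first, only, known or untested is meant among the compounds shown, and "the series" means these compounds.

Compound 1, `CCc1cccc(CNC(=O)c2nc3ccc(F)c(COc4ccc(C(=O)O)cc4)c3c(=O)[nH]2)c1`, in an ADME assay on HEK293 cells (Homo sapiens) for cytotoxicity, read by resazurin assay, with a stated time of 72 h (on this read-out lower numbers stand for higher toxicity in this test and higher numbers for lower toxicity in this test), gives > 20000 nM, a limit of the assay rather than a number.
Compound 2, `CCc1cccc(CNC(=O)c2nc3ccc(F)c(COCc4ccc(C(=O)O)cc4)c3c(=O)[nH]2)c1`, gives > 20000 nM, again only a limit.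
Compound 3, `CCc1cccc(CNC(=O)c2nc3cccc(COc4ccc(C(=O)O)cc4)c3c(=O)[nH]2)c1`, gives > 20000 nM, also a limit.

The change from compound 1 to compound 2 is 4-carboxybenzyl in place of 4-carboxyphenyl on an oxygen on a saturated carbon. Its step, a step that the two limits leave unreadable from compound 1 to compound 2, cannot be sized, since both ends are limits. Compound 3 differs from compound 1 in its core by hydrogen in place of fluoro on an aromatic carbon, and that step, a step that the two limits leave unreadable from compound 1 to compound 3, is equally unreadable. For the measured compounds named here, compound 4, `CCc1cccc(CNC(=O)c2nc3cccc(COCc4ccc(C(=O)O)cc4)c3c(=O)[nH]2)c1`, has not yet been measured; it carries the same change as the one from compound 1 to compound 2, namely (4-carboxybenzyl in place of 4-carboxyphenyl on an oxygen on a saturated carbon), placed on the core of compound 3.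

The expectation for the step from compound 3 to compound 4 in this assay is a step that the limit leaves unreadable from compound 3 to compound 4, resting on (the limit of > 20000 nM in this assay, at which 3 of the 3 values shown sit), which shows no toxicity signal anywhere in this set. Compound 4 is therefore estimated at 30000 nM, most likely reported again only as a limit, with a plausible range of 12000 nM to 80000 nM.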

Compound 4, half-maximal cytotoxic concentration: > 40000 nM
Compound 4: a limit, no number; the forecaster's own chance of this, stated with the estimate: 85%; middle value at least 1.3-fold (0.12 log units) away from the limit.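

In this assay compound 4 gives > 40000 nM, which is again a limit and not a number. With limits at both ends, no step can be read from compound 3 to compound 4 or from compound 2 to compound 4. The compounds shown leave open at what concentration, if any, each would become toxic to these cells, and whether either change alters that concentration.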